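Sulfonamide in place of amide on the alkyne-linked ring

This account rests on a few compounds, and the source may have more. Where it says the series, first, only, none or still open, it means among the compounds named here.

In an assay on CHO cells for displacement of a labelled ligand from prostaglandin D2 receptor 2 (Homo sapiens), read by scintillation counting (on this read-out lower numbers stand for stronger inhibition and higher numbers for weaker inhibition), compound 2 `CN(C)C(=O)c1cccc(C#Cc2cc(Cl)ccc2OCC(=O)O)c1` gives 52 nM, the second highest of three numbers. Compound 1 `CCCS(=O)(=O)c1cccc(C#Cc2cc(Cl)ccc2OCC(=O)O)c1` gives 9 nM, and compound 3 `COc1ccccc1C#Cc1cc(Cl)ccc1OCC(=O)O` gives 190 nM. Among the compounds with values here, the one step bearing on the new compound is a 5.8-fold higher number from compound 1 to compound 2 (0.76 log units; beyond the scatter), where dimethylcarbamoyl replaced propylsulfonyl. Compound 4 `CN(c1cccc(C#Cc2cc(Cl)ccc2OCC(=O)O)c1)S(C)(=O)=O` carries methyl(methylsulfonyl)amino in place of dimethylcarbamoyl on an aromatic carbon. Within the data shown here, the entering group, like propylsulfonyl in compound 1, contains a sulfonyl unit, so a modest step back toward lower numbers is expected, though the methylsulfonyl is attached through nitrogen rather than directly, and no measured pair shows that exact change. The expected step is a 2.6-fold lower number from compound 2 to compound 4 (0.41 log units; beyond the scatter). Compound 4 is therefore estimated at 20 nM, with a range from 6 nM to 70 nM.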

Compound 4, inhibition constant: 122 nM
For compound 4 the middle estimate is 6.1-fold (0.79 log units) below the measured one; measured number above the stated range.
By their numbers in this assay, from the lowest: compound 1; then compound 2; then compounds 4 and 3 (each within the scatter of the next).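

In this assay, methyl(methylsulfonyl)amino in place of dimethylcarbamoyl gives a 2.3-fold higher number from compound 2 to compound 4 (0.37 log units; beyond the scatter), and in place of propylsulfonyl it gives a 14-fold higher number from compound 1 to compound 4 (1.13 log units; beyond the scatter). At this position, then, having a sulfonyl unit in the group is not enough to reach the low number of compound 1: the sulfonyl attached through nitrogen in compound 4 does worse than both the directly attached propylsulfonyl and the sulfonyl-free dimethylcarbamoyl. As far as these compounds go, it remains open how a methylsulfonyl attached directly to the aromatic carbon would read, which would separate the effect of the nitrogen link from that of the shorter chain. Nothing measured here gives a reason for these differences.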